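Configuration swap in a bis-ester pair: working notes

A few compounds are considered here, and "the series" means these few. Any claim that something is new, unique, unknown or untested is made for them only; others in the source may bear on it.

Measured so far:
compound 1 `COc1cc(/C=C/C(=O)/C=C(O)/C=C/c2ccc(OC(=O)[C@@H](CCSC)NC(=O)OCc3ccccc3)c(OC)c2)ccc1OC(=O)[C@@H](CCSC)NC(=O)OCc1ccccc1` — 90%
compound 2 `COc1cc(/C=C/C(=O)/C=C(O)/C=C/c2ccc(OC(=O)[C@H](CC(C)C)NC(=O)OCc3ccccc3)c(OC)c2)ccc1OC(=O)[C@H](CC(C)C)NC(=O)OCc1ccccc1` — 1%

In a functional assay on the whole organism (strain Wistar) for inhibition, with Rattus norvegicus as the target, read by paw edema, with stated times of 1 h and 24 h, at a dose of 10 mg/kg by the intraperitoneal route (on this read-out higher numbers stand for more inhibition at the one dose given (going by the name of the read-out) and lower numbers for less inhibition), compound 1 gives 90%, the higher of the two numbers in hand. Compound 2 gives 1% in this assay, a number far below that of compound 1 and beyond the scatter; on the two values alone compound 1 stands at the top of this small set.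

Compound 3 `COc1cc(/C=C/C(=O)/C=C(O)/C=C/c2ccc(OC(=O)[C@H](CCSC)NC(=O)OCc3ccccc3)c(OC)c2)ccc1OC(=O)[C@H](CCSC)NC(=O)OCc1ccccc1` is the unmeasured partner of compound 1: the two compounds have the same atoms and bonds and differ only in configuration as drawn: 2 of 5 stereo elements differ; a stereocentre at a saturated chain carbon is drawn R in compound 1 and S in compound 3; a stereocentre at a saturated chain carbon is drawn R in compound 1 and S in compound 3. Among the measured compounds shown here, no measured pair in this set differs in configuration alone, so there is no step of this kind to lean on, and the gap between compound 1 and compound 2 cannot serve as one.

The step expected in this assay is a number 25 percentage points lower from compound 1 to compound 3 (beyond the scatter), a moderate fall that could still end within the scatter. The estimate for compound 3 is 65%, with a wide range from 15% to 95%.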

Compound 3, a percentage reported as inhibition, in the whole organism at one dose (the size of the read-out at that dose, not a potency): 94%
For compound 3 the middle estimate is 29 percentage points below the measured one; the range from low to high includes it.
By their numbers in this assay, from the lowest: compound 2; then compounds 1 and 3 (each within the scatter of the next).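

This pair is the only one in the series that isolates configuration, and in this assay it gives a number 4 percentage points higher from compound 1 to compound 3 (within the scatter). At this one dose, therefore, redrawing both saturated chain stereocentres from R to S leaves no readable difference in paw edema inhibition, which neither earlier compound could show alone. The reading holds only for this pair: the fact that compounds 1 and 3 differ only in the configuration as drawn.

Going by these compounds, whether the same insensitivity to configuration holds at lower doses, where the read-out is not close to its upper end, stays open, and a single-dose percentage gives no potency. Also open, on these data alone, is whether it carries over to the chain of compound 2, or what an amine or a longer chain in that place would do in this assay.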